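Benzylpurine series: dropping the second ring chloro

The source may hold more compounds than are shown below. What is called first, only, known or untested is meant among the compounds shown, and "the series" means these compounds.

Measured so far, each in a functional assay on M14 cells (Homo sapiens) for cytotoxicity, read by sulforhodamine B assay, with a stated time of 48 h; a higher number here means that more compound is tolerated, a lower number that less compound is tolerated:
- compound 1 `ClCc1ccc(Cn2cnc3c(Cl)ncnc32)cc1`: 9120 nM
- compound 2 `ClCc1ccccc1Cn1cnc2c(Cl)nc(Cl)nc21`: 5750 nM

Compound 2 holds the lowest of the two numbers; its nearest neighbour is compound 1, whose number is higher but within the scatter, so no order between the two can be read from the data. Among the measured compounds shown here, the pair differs in more than one place and yields no single-change step.

Compound 3 `ClCc1ccccc1Cn1cnc2c(Cl)ncnc21` is reached from compound 2 by one change: hydrogen in place of chloro on an aromatic carbon. For the measured compounds named here, no single-change step between measured compounds is available, so the size of this step has to be guessed. Compound 1, which carries hydrogen at that place on its own core, gives 9120 nM in this assay, a number not separated from that of compound 2 by more than the scatter. On that basis only a small shift toward a higher number is expected, not clearly beyond the scatter, as a 1.4-fold higher number from compound 2 to compound 3 (0.14 log units; within the scatter). Compound 3 is therefore estimated at 8000 nM, with a range from 3000 nM to 22000 nM.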

Compound 3, concentration lethal to 50% of the cells: 7240 nM
Beside the measured number, compound 3's estimate is 1.1-fold (0.04 log units) above it, within the range that was stated.
By their numbers in this assay, from the lowest: compounds 2, 3 and 1 (each within the scatter of the next).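

Among the compounds shown here, the first single-change step is hydrogen in place of chloro on an aromatic carbon, between two ring nitrogen atoms, and in this assay it reads a 1.3-fold higher number from compound 2 to compound 3 (0.10 log units; within the scatter) and so gives no order between the two compounds. At this place, then, the loss of one chlorine atom produces no shift that can be separated from the scatter, which the earlier pair could not show because it differs in more than one place. No measurement shown bears on the reason for this result.

From the compounds shown here alone, the finding rests on a single pair and covers only hydrogen and chloro at this place, so whether an amine, a methoxy group or a longer chain there would move the number beyond the scatter remains open. Also open, going by these compounds, is whether the same holds for the other chloro group, which stays on the ring in both compounds and is meta to the place of change, and whether an amine in that position would leave the number within the scatter as well.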